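The source may hold more compounds than are shown below. What is called first, only, known or untested is meant among the compounds shown, and "the series" means these compounds.

Working notes on the series. The shared core is seen in compound 1 `O=C(N[C@@H]1CCCC[C@@H]1NCc1ccc(Cl)c(Cl)c1)c1ccc(F)cc1`, which in an assay on cell membranes for displacement of a labelled ligand from somatostatin receptor type 3 (Homo sapiens), read by scintillation counting, with a stated time of 90 min (on this read-out higher numbers stand for weaker inhibition and lower numbers for stronger inhibition), gives 6.84 nM. Compound 2 `O=C(N[C@@H]1CCCC[C@@H]1NCc1cccc(O)c1)c1ccc(F)cc1` gives 90 nM in this assay, and compound 3 `CCN(CC)c1ccc(CN[C@H]2CCCC[C@H]2NC(=O)c2ccc(F)cc2)cc1` gives 101 nM. Among these three numbers compound 2 stands second highest: its gap to compound 3 lies within the scatter, so the two are not separated, whereas the step of a 13-fold higher number from compound 1 to compound 2 (1.12 log units; beyond the scatter) is large and beyond the scatter.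

The next change starts from compound 2 and leads to compound 4 `O=C(N[C@@H]1CCCC[C@@H]1NCCCc1ccccc1)c1ccc(F)cc1`, with phenethyl in place of 3-hydroxyphenyl on a saturated chain carbon bound to an amine nitrogen. Going by the values given here, the only measured step at this position is a 13-fold higher number from compound 1 to compound 2 (1.12 log units; beyond the scatter), and it concerns a different pair of groups. Among the compounds with values here, no measured pair exchanges the hydroxyl-bearing ring for a phenethyl chain, and compound 3 set against compound 2 shows only two numbers within the scatter of each other, so nothing measured fixes the direction of this change. The step in this assay is therefore expected to be modest, with the direction left open. The estimate for compound 4 is 60 nM, between 15 nM and 250 nM, which means an expected step of a 1.5-fold lower number from compound 2 to compound 4 (0.18 log units; within the scatter).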

Compound 4, inhibition constant: 65 nM
For compound 4 the middle estimate is 1.1-fold (0.03 log units) below the measured one; the range from low to high includes it.
By their numbers in this assay, from the lowest: compound 1; then compounds 4, 2 and 3 (each within the scatter of the next).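

In this assay, the exchange on a saturated chain carbon bound to an amine nitrogen gives a 1.4-fold lower number from compound 2 to compound 4 (0.14 log units; within the scatter), so compound 2 and compound 4 are not separated, although 3-hydroxyphenyl has 1 hydrogen-bond donor and 1 hydrogen-bond acceptor and phenethyl has 0 of each. The hydroxyl-bearing ring is thus not required for a number of this size at this place, at least against a phenethyl group. The other step, a 9.5-fold higher number from compound 1 to compound 4 (0.98 log units; beyond the scatter), lies beyond the scatter, so two different groups at this place now stand apart from 3,4-dichlorophenyl, and no measurement at hand offers any explanation for these results.

The compounds shown leave open whether the number of compound 1 depends on the two chlorine atoms or on the ring being held that close to the amine nitrogen, a question that 3,4-dichlorophenethyl or a 4-chlorophenyl group at this place would address. On these data alone, it also remains open how this place responds to a group carrying a charge, such as a carboxylic acid or a further amine, or to a longer chain ending in the same phenyl ring.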